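A Ring Gives Way to an Open Chain

The compounds below may be only part of what the source reports. "The series", "measured", "known", "first", "only" and "open" are said of these compounds alone.

In a functional assay on MCF7 cells (Homo sapiens) for inhibition, read by MTT assay, with a stated time of 3 days (a lower number here means a stronger inhibitor, a higher number a weaker inhibitor), compound 1 `COc1cc(-c2nc3ccccc3s2)ccc1OCC(=O)NNC(=O)CCl` gives 780 nM. Compound 2 `CC[C@H](C)[C@H](NCC(=O)NNC(=O)COc1ccc(-c2nc3ccccc3s2)cc1OC)C(=O)O` gives 1710 nM. Compound 3 `COc1cc(-c2nc3ccccc3s2)ccc1OCC(=O)NNC(=O)CN1CCC[C@H]1C(=O)O` gives 840 nM, which lies within the scatter of compound 1 and is a lower number than that of compound 2.

Compound 4 `CCOC(=O)[C@H](CCSC)NCC(=O)NNC(=O)COc1ccc(-c2nc3ccccc3s2)cc1OC` has not yet been measured. It carries (1-(ethoxycarbonyl)-3-(methylsulfanyl)propyl)amino in place of 2-carboxypyrrolidin-1-yl on a saturated chain carbon bound to a carbonyl carbon.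

Going by the values given here, three measured steps bear on this change. Replacing chloro gave a 1.1-fold higher number from compound 1 to compound 3 (0.03 log units; within the scatter) and a 2.2-fold higher number from compound 1 to compound 2 (0.34 log units; beyond the scatter). The closest comparison is a 2.0-fold lower number from compound 2 to compound 3 (0.31 log units; beyond the scatter), where an open-chain amino group gives way to the ring. Reversing that modest step suggests a somewhat higher number, but no measured compound carries an ester or a sulfur atom, so the direction is uncertain. The expected change is a 1.3-fold higher number from compound 3 to compound 4 (0.12 log units; within the scatter). Compound 4 is estimated at 1100 nM, with an expected range of 450 nM to 2700 nM.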

Compound 4, half-maximal inhibitory concentration: 1760 nM
The estimate for compound 4 lay 1.6-fold (0.20 log units) below the measured number, and the stated range covers the measured number.
By their numbers in this assay, from the lowest: compounds 1 and 3 (each within the scatter of the next); then compounds 2 and 4 (each within the scatter of the next).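

In this assay the step to the open chain (1-(ethoxycarbonyl)-3-(methylsulfanyl)propyl)amino is a 2.1-fold higher number from compound 3 to compound 4 (0.32 log units; beyond the scatter) and the step from chloro is a 2.3-fold higher number from compound 1 to compound 4 (0.35 log units; beyond the scatter), both modest, so on this saturated chain carbon bound to a carbonyl carbon both open-chain amino groups now stand apart from 2-carboxypyrrolidin-1-yl and from chloro. The two open chains are not told apart, with a 1.0-fold higher number from compound 2 to compound 4 (0.01 log units; within the scatter) on the amine nitrogen, even though only compound 4 carries an ethyl ester and a sulfur atom. No measurement shown here accounts for these steps.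

On these data alone, the ester and the carboxylic acid are never compared on the same chain, so the part each plays stays open. Also open, as far as these compounds go, is how a simple primary amine or the ethyl ester of 2-carboxypyrrolidin-1-yl would read at this place.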